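Replacing a Larger Aromatic Group with 2-Fluorophenyl

The source may hold more compounds than are shown below. What is called first, only, known or untested is meant among the compounds shown, and "the series" means these compounds.

Compound 1 `O=C(NCCCCc1ccccc1)c1cccc(C2SCC(=O)N2c2cccc(-c3c[nH]nn3)c2)c1` holds the only measured number shown: in a functional assay on HOS-TE85 cells (Homo sapiens) for inhibition, read by CCK-8 assay, with a stated time of 72 h (on this read-out higher numbers stand for weaker inhibition and lower numbers for stronger inhibition), compound 1 gives 110 nM. Compound 2 `COc1ccccc1N1C(=O)CSC1c1cccc(C(=O)NCCCCN2CCN(C(=O)OC(C)(C)C)CC2)c1` reaches only a limit of this assay, > 1000 nM, which is the limit of > 1000 nM in this assay, at which 1 of the 2 values shown sits, and offers no number to compare. Compound 3 `O=C(NCCCCc1ccccc1)c1cccc(C2SCC(=O)N2c2ccccc2F)c1` differs from compound 1 by a group of 7 heavy atoms (6 carbon, 1 fluorine; one six-membered aromatic ring of carbon only) in place of a group of 11 heavy atoms (8 carbon, 3 nitrogen; one five-membered aromatic ring with 3 hetero atoms, one six-membered aromatic ring of carbon only), on an amide-type nitrogen in a ring. Going by the values given here, no measured pair shows a change of this kind, so its size is unknown from the data. The expected step is a 4.5-fold higher number from compound 1 to compound 3 (0.66 log units; beyond the scatter) in this assay, toward weaker inhibition, beyond the usual scatter. Compound 3 is therefore estimated at 500 nM, with a likely range from 150 nM to 3000 nM.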

Compound 3, half-maximal inhibitory concentration: 34.1 nM
Compound 3: middle estimate off by 15-fold (1.17 log units), on the high side, outside the stated range (below it).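

Swapping the larger two-ring group on the amide-type nitrogen in the ring for 2-fluorophenyl gives, in this assay, a 3.2-fold lower number from compound 1 to compound 3 (0.51 log units; beyond the scatter). Inhibition at this position therefore does not depend on the five-membered aromatic ring with 3 hetero atoms or its hydrogen-bond donor. Nothing measured here explains why the number falls.

From the compounds shown here alone, how an unsubstituted phenyl or a 2-chlorophenyl group would compare with 2-fluorophenyl remains open. Compound 2 differs from compound 3 in more than one place, so it cannot settle this.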